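This account rests on a few compounds, and the source may have more. Where it says the series, first, only, none or still open, it means among the compounds named here.

Measured so far: compound 1 `CCS(=O)(=O)Nc1ccc(Oc2ccccc2)c(-c2cn(C)c(=O)c3[nH]ccc23)c1`; compound 2 `Cn1cc(-c2cc(C(N)=O)ccc2Oc2ccccc2)c2cc[nH]c2c1=O`; compound 3 `Cn1cc(-c2cc(NS(C)(=O)=O)ccc2Oc2ccc(F)cc2F)c2cc[nH]c2c1=O`.

In an ADME assay on microsomes from liver (Homo sapiens) for metabolic stability, read by HPLC, using NADPH, with stated times of 5 min and 60 min, tested at 10 uM (a lower number here means slower removal, a higher number faster removal of the compound), compound 1 gives only a limit of the assay, < 45 mL/min/kg. In this assay compound 2 gives 48.3 mL/min/kg. In this assay compound 3 gives 155 mL/min/kg, the higher of the two numbers measured in the series. For the measured compounds named here, the one measured step, an at least 1.0-fold higher number from compound 1 to compound 2 (0.03 log units; that floor lies within the scatter), concerns a different position and lies within the scatter, so it gives no guidance here. Compound 4 `Cn1cc(-c2cc(NS(C)(=O)=O)ccc2OC2CCC(F)(F)CC2)c2cc[nH]c2c1=O` differs from compound 3 by 4,4-difluorocyclohexyl in place of 2,4-difluorophenyl on an oxygen on an aromatic ring. Going by the values given here, no measured step touches this position, and no direction beyond the scatter can be read from the data. The estimate for compound 4 is 130 mL/min/kg, with a range of 60 mL/min/kg to 280 mL/min/kg. The expected step, a 1.2-fold lower number from compound 3 to compound 4 (0.08 log units; within the scatter), is taken as lying within the scatter.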

Compound 4, clearance: < 38.4 mL/min/kg
Compound 4 gave a limit, no number (the forecaster's own chance of this, stated with the estimate: 10%); middle value at least 3.3-fold (0.52 log units) away from the limit.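

In this assay, for the compounds shown here, the group on the oxygen on an aromatic ring turns out to matter, a position no earlier step touched: 4,4-difluorocyclohexyl in place of 2,4-difluorophenyl gives an at least 4.0-fold lower number from compound 3 to compound 4 (0.60 log units; beyond the scatter). The two groups count the same heavy atoms and differ in the ring being non-aromatic rather than aromatic. The size of this step is only a floor, since compound 4 gives a limit of the assay: the limit of < 38.4 mL/min/kg in this assay, at which 1 of the 4 values shown sits.

Open, as far as these compounds go, is whether the fluorines take part, which a plain cyclohexyl group on the same oxygen would address. Also open, from the compounds shown here alone, is whether the step holds with the (ethylsulfonyl)amino group of compound 1 or the carbamoyl group of compound 2.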